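The source may report more compounds than this note shows. Statements on the series, on what has been measured and on what is new or still open speak of the compounds shown alone.

Working notes on the series. In an ADME assay on MT4 cells (Homo sapiens) for cytotoxicity, read by MTT assay (a lower number here means that less compound is tolerated, a higher number that more compound is tolerated), compound 1 `CCc1c(Cc2c(Cl)cccc2Cl)nc(SCC(=O)c2ccccc2)[nH]c1=O` gives > 52000 nM, which is a limit of the assay and not a number. Compound 2 `CCc1c(Cc2c(Cl)cccc2Cl)nc(SCC(=O)c2ccc(F)cc2)[nH]c1=O` gives > 55000 nM, which is also a limit. Among the measured compounds shown here, no plain number exists yet in this assay, so compound 1 cannot be ranked against the only other compound measured.

Compound 3 `CCc1c(Cc2c(F)cccc2Cl)nc(SCC(=O)c2ccccc2)[nH]c1=O` is next, and it differs from compound 1 as follows: fluoro in place of chloro on an aromatic carbon. In words, this is fluoro in place of chloro on an aromatic carbon, turning 2,6-dichlorobenzyl into 2-chloro-6-fluorobenzyl. For the measured compounds named here, the one measured step that bears on this change is a step that the two limits leave unreadable from compound 1 to compound 2, and it is only a loose guide, since there fluoro replaces hydrogen rather than chloro. With no readable size from that step, no step beyond the scatter is expected in this assay, in either direction. The estimated step is a step that the limit leaves unreadable from compound 1 to compound 3. For compound 3 the expected value is 55000 nM, with an estimated range of 25000 nM to 110000 nM, and another limit rather than a number is the likely report.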

Compound 3, half-maximal cytotoxic concentration: > 12000 nM
Compound 3 gave a limit, no number (the forecaster's own chance of this, stated with the estimate: 75%); the middle value does not contradict the limit.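

In this assay compound 3 gives > 12000 nM, which is a limit of the assay and not a number. Compound 1 also stands at a limit, so no step can be read between compound 1 and compound 3. The compounds shown leave open whether fluoro in place of chloro changes the half-maximal cytotoxic concentration at all.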